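From methyl to tert-butoxy: working notes on compound 3

The source may hold more compounds than are shown below. What is called first, only, known or untested is meant among the compounds shown, and "the series" means these compounds.

Measured so far in a functional assay on A-431 cells (Homo sapiens) for inhibition, read by MTT assay, with a stated time of 72 h; a lower number here means a stronger inhibitor, a higher number a weaker inhibitor:
Compound 1 `Cc1ccc(-c2nnc(SCCCN3CCN(c4nc5ccccc5o4)CC3)o2)cc1`: 100000 nM
Compound 2 `Cc1ccc(-c2nnc(SCCCN3CCN(c4nc5ccccc5s4)CC3)o2)cc1`: 61600 nM

Only these two compounds have numbers, and they lie within the scatter of each other, so compound 2 cannot be ranked apart from compound 1. Among the measured compounds shown here, the single measured step is a 1.6-fold lower number from compound 1 to compound 2 (0.21 log units; within the scatter). It comes from 1,3-benzothiazol-2-yl in place of 1,3-benzoxazol-2-yl on an amine nitrogen in a ring.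

Compound 3 `CC(C)(C)Oc1ccc(-c2nnc(SCCCN3CCN(c4nc5ccccc5s4)CC3)o2)cc1` keeps all of compound 2 except one group: tert-butoxy in place of methyl on an aromatic carbon. In words, this is tert-butoxy in place of methyl on an aromatic carbon, or 4-methylphenyl to 4-(tert-butoxy)phenyl.

For the measured compounds named here, no measured step covers a change at this place. The step between compound 1 and compound 2 lies elsewhere in the molecule and offers only a weak guide, so no step beyond the scatter is expected in this assay, and the data do not settle its direction. For compound 3 the estimated value is 50000 nM, with an expected range of 15000 nM to 100000 nM. This estimate means an expected 1.2-fold lower number from compound 2 to compound 3 (0.09 log units; within the scatter).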

Compound 3, half-maximal inhibitory concentration: 67000 nM
Beside the measured number, compound 3's estimate is 1.3-fold (0.13 log units) below it, and the stated range covers the measured number.
By their numbers in this assay, from the lowest: compounds 2, 3 and 1 (each within the scatter of the next).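

In this assay, among the compounds shown here, the first change at this place, 4-methylphenyl to 4-(tert-butoxy)phenyl, reads as a 1.1-fold higher number from compound 2 to compound 3 (0.04 log units; within the scatter), a step that lies within the scatter. On an aromatic carbon para to a large group, the swap from methyl, with 1 heavy atom and no hydrogen-bond acceptor, to tert-butoxy, with 5 heavy atoms and 1 hydrogen-bond acceptor, therefore gives no readable shift in this assay, although neither compound 1 nor compound 2 had shown anything about this position. Nothing at hand bears on why the reading stays flat.

From the compounds shown here alone, whether an amine, a carboxylic acid or a hydroxy group at this place would give a step beyond the scatter remains open, since one pair tests only a single replacement. Also open, going by these compounds, is whether tert-butoxy would read the same with 1,3-benzoxazol-2-yl in place of 1,3-benzothiazol-2-yl on the ring amine nitrogen, and whether a shorter or longer chain to the sulfur would change the picture for the series.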